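This account rests on a few compounds, and the source may have more. Where it says the series, first, only, none or still open, it means among the compounds named here.

Measured so far in an assay on HEK-293T cells for inhibition of phospholipase A and acyltransferase 5 (Homo sapiens), with stated times of 30 min and 20 min; on this read-out higher numbers stand for weaker inhibition and lower numbers for stronger inhibition:
compound 1 `O=C(CCc1ccc(Cl)cc1)C(=O)NCCCCc1ccccc1` – 200 nM
compound 2 `CCNC(=O)C(=O)CCc1ccc(Cl)cc1` – 1000 nM
compound 3 `CN1CCN(C(=O)C(=O)CCc2ccc(Cl)cc2)CC1` – a limit only

Compound 3 reaches only the limit > 10000 nM in this assay. Of the two numbers that are real values, compound 2 therefore stands with the higher one, and its nearest neighbour is compound 1, with a 5.0-fold higher number from compound 1 to compound 2 (0.70 log units; beyond the scatter), a modest step that concerns the group carried by the amide nitrogen.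

Compound 4 `O=C(CCc1ccc(Cl)cc1)C(=O)N1CCCC1` has not yet been measured in this assay. It differs from compound 2 by pyrrolidin-1-yl in place of ethylamino on a carbonyl carbon. Among the measured compounds shown here, the only measured step that touches the same part of the molecule is a 5.0-fold higher number from compound 1 to compound 2 (0.70 log units; beyond the scatter), and it was of moderate size. Compound 3, a tertiary amide as compound 4 would be, sits at the limit of > 10000 nM in this assay, at which 1 of the 3 values shown sits. A rise in the number, that is weaker inhibition, is therefore expected from compound 2 to compound 4, a 5.0-fold higher number from compound 2 to compound 4 (0.70 log units; beyond the scatter). Compound 4 is estimated at 5000 nM, within a range from 1500 nM to 20000 nM, with a fair chance that only a limit is reported.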

Compound 4, half-maximal inhibitory concentration: > 10000 nM
Compound 4 ended at the assay's limit; the forecaster's own chance of this, stated with the estimate: 35%; middle value at least 2.0-fold (0.30 log units) from the limit.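

In this assay, pyrrolidin-1-yl in place of ethylamino on a carbonyl carbon gives an at least 10-fold higher number from compound 2 to compound 4 (1.00 log units; beyond the scatter), a step larger than the one seen with the chain change on the amide nitrogen, and its full size stays hidden at the limit. Compound 4 gives only a limit, > 10000 nM. Among the compounds shown, those that keep the amide hydrogen, compound 1 and compound 2, give real values, whereas compound 3 and compound 4, which lack it, both stop at the limit: the limit of > 10000 nM in this assay, at which 2 of the 4 values shown sit.

The compounds shown leave open whether the amide hydrogen or the ring accounts for this change. A cyclopentylamino group would keep that hydrogen and carry a ring, while a diethylamino group would lack the hydrogen and carry no ring.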